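The compounds below may be only part of what the source reports. "The series", "measured", "known", "first", "only" and "open" are said of these compounds alone.

In a functional assay on B16-F10 cells (Mus musculus) for cytotoxicity, read by MTT assay, with a stated time of 72 h (a lower number here means a stronger inhibitor, a higher number a weaker inhibitor), two compounds sharing a five-ring core have been measured. Compound 1 `COc1ccc2[nH]c3c4cn[nH]c4c4c(c3c2c1)C(=O)NC4=O` gives 37000 nM. Compound 2 `Cc1ccc2[nH]c3c4cn[nH]c4c4c(c3c2c1)C(=O)NC4=O` gives 2000 nM. The change between them is methyl in place of methoxy on an aromatic carbon, and it brings a 19-fold lower number from compound 1 to compound 2 (1.27 log units; beyond the scatter).

Compound 3 `COc1ccc2[nH]c(-n3cccn3)cc2c1` is built on a smaller, two-ring core; how the two cores differ is not broken down here. In this assay compound 3 reaches only > 100000 nM, which is a limit of the assay and not a number, the point at which (the limit of > 100000 nM in this assay, at which 1 of the 3 values shown sits).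

Compound 4 `Cc1ccc2[nH]c(-n3cccn3)cc2c1` has not yet been measured. It differs from compound 3 by methyl in place of methoxy on an aromatic carbon. This is the same kind of change as that from compound 1 to compound 2, though not the same: in compound 1 the ring carrying the group is part of a fused or bridged system of five rings, whereas in compound 3 it is part of a fused or bridged system of two rings.

If the change acts as before, a step of about an at least 1.2-fold lower number from compound 3 to compound 4 (0.09 log units; that floor lies within the scatter) is expected from compound 3 to compound 4, resting on a 19-fold lower number from compound 1 to compound 2 (1.27 log units; beyond the scatter). Because the starting point for compound 3 is only the limit > 100000 nM, the expected position of compound 4 is uncertain. Compound 4 is estimated at 80000 nM, with a likely span from 20000 nM to 300000 nM.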

Compound 4, half-maximal inhibitory concentration: > 100000 nM
Compound 4: only a limit was reported (the forecaster's own chance of this, stated with the estimate: 55%); at least 1.2-fold (0.09 log units) between middle value and limit.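

In this assay, compound 3 and compound 4 both sit at a limit of the assay and not at a number, so the step between them cannot be read: the limit of > 100000 nM in this assay, at which 2 of the 4 values shown sit.

The compounds shown leave open whether methyl in place of methoxy changes activity at all on the core of compound 3, as it does on the core of compound 1.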